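The compounds below may be only part of what the source reports. "The series", "measured", "known", "first", "only" and "open" are said of these compounds alone.

In a functional assay on A2780 cells (Homo sapiens) for antiproliferative activity, read by MTT assay, with a stated time of 72 h (a lower number here means a stronger inhibitor of growth, a higher number a weaker inhibitor of growth), compound 1 (`COc1cc(OC)c(/C=C/S(=O)(=O)Cc2cnc(OC)cn2)c(OC)c1`) gives 490 nM, compound 2 (`COc1cc(OC)c(/C=C/S(=O)(=O)Nc2ccc(OC)nc2)c(OC)c1`) gives 380 nM, and compound 3 (`CCOc1cc(OC)cc(OC)c1/C=C/S(=O)(=O)Nc1ccc(OC)nc1`) gives 470 nM. These three numbers lie within the usual scatter of one another, so compound 1 stands level with the other two.

Compound 4 (`COc1cc(OC)c(/C=C/S(=O)(=O)Cc2nc(N)ncc2OC)c(OC)c1`) has not yet been measured. It keeps the core of compound 1 and changes one group: 2-amino-5-methoxypyrimidin-4-yl in place of 5-methoxypyrazin-2-yl on a saturated chain carbon bound to a sulfonyl sulfur.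

For the measured compounds named here, the only measured single change is a 1.2-fold higher number from compound 2 to compound 3 (0.09 log units; within the scatter). It is a small change in another place, on a saturated chain carbon bound to an oxygen on an aromatic ring, so it says little about this exchange. Going by the values given here, no measured step touches the saturated chain carbon bound to a sulfonyl sulfur. Exchanging a whole ring group is a larger edit, so a somewhat higher number in this assay is the cautious expectation, though the direction remains uncertain. The expected step is a 2.0-fold higher number from compound 1 to compound 4 (0.31 log units; beyond the scatter). For compound 4 the estimated value is 1000 nM, with an expected range from 200 nM to 5000 nM.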

Compound 4, concentration for 50% growth inhibition: > 10000 nM
Compound 4: only a limit was reported; the forecaster's own chance of this, stated with the estimate: 5%; middle value at least 10-fold (1.00 log units) from the limit.
By their numbers in this assay, from the lowest: compounds 2, 3 and 1 (each within the scatter of the next). At a limit, above all of these: compound 4.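

In this assay, the exchange of 5-methoxypyrazin-2-yl for 2-amino-5-methoxypyrimidin-4-yl on a saturated chain carbon bound to a sulfonyl sulfur gives an at least 20-fold higher number from compound 1 to compound 4 (1.30 log units; beyond the scatter). For the compounds shown here, the only earlier step, a 1.2-fold higher number from compound 2 to compound 3 (0.09 log units; within the scatter), lay elsewhere on the molecule, so this is the first sign that the group at this position can matter greatly for growth inhibition. Compound 4 has only a limit, so the full size of the step remains unknown: the limit of > 10000 nM in this assay, at which 1 of the 4 values shown sits.

The exchange alters the ring group and adds an amine together, and the compounds shown cannot separate these two changes. On these data alone, it remains open whether the same ring without the amine, or with an acetamide in place of the amine, would restore growth inhibition.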